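Nitro for bromo in a weakly antiproliferative oxadiazole series

The compounds below may be only part of what the source reports. "The series", "measured", "known", "first", "only" and "open" are said of these compounds alone.

Of the compounds shown here, three from the same core have been measured in a functional assay on HepG2 cells (Homo sapiens) for antiproliferative activity, read by MTT assay, with a stated time of 24 h; on this read-out higher numbers stand for weaker inhibition and lower numbers for stronger inhibition. Compound 1 `Brc1cccc(-c2nnc(Cn3nnc4ccccc43)o2)c1` gives 488000 nM, compound 2 `Brc1ccc(-c2nnc(Cn3nnc4ccccc43)o2)cc1` gives 438000 nM, and compound 3 `Clc1cccc(-c2nnc(Cn3nnc4ccccc43)o2)c1` gives 440000 nM. Compound 2 holds the lowest of the three numbers, yet its neighbours sit close: a 1.1-fold lower number from compound 1 to compound 2 (0.05 log units; within the scatter), a 1.0-fold higher number from compound 2 to compound 3 (0.00 log units; within the scatter), and a 1.1-fold lower number from compound 1 to compound 3 (0.04 log units; within the scatter), so none of these steps leaves the scatter and no order among the three can be claimed.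

Compound 4 `O=[N+]([O-])c1ccc(-c2nnc(Cn3nnc4ccccc43)o2)cc1` differs from compound 2 by nitro in place of bromo on an aromatic carbon. Among the compounds with values here, no measured step replaces a halogen with a nitro group, so the measured steps bear on it only indirectly: they show that moving the bromo substituent or swapping it for chloro left the number essentially unchanged. On that basis the step from compound 2 to compound 4 is expected to be small, a 1.0-fold higher number from compound 2 to compound 4 (0.00 log units; within the scatter), with no direction favoured. Compound 4 is therefore estimated at 440000 nM in this assay, within a range from 180000 nM to 1100000 nM.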

Compound 4, half-maximal inhibitory concentration: 483000 nM
For compound 4 the middle estimate is 1.1-fold (0.04 log units) below the measured one, and the stated range covers the measured number.
By their numbers in this assay, from the lowest: compounds 2, 3, 4 and 1 (each within the scatter of the next).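

With nitro in place of bromo on an aromatic carbon, para to a large group, this assay gives a 1.1-fold higher number from compound 2 to compound 4 (0.04 log units; within the scatter). Within the data shown here, this is the first step here that leaves the halogens behind: the group that enters has 3 heavy atoms and 2 hydrogen-bond acceptors, the one that leaves has 1 heavy atom and 0 hydrogen-bond acceptors, and still the number stays within the scatter. Nothing available explains why this position shows so little response to the exchange.

Going by these compounds, it remains open whether an amine or a carboxylic acid at this position would also stay within the scatter of compound 2. The compounds shown also leave open whether any change to the shared core could move the number beyond the scatter.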